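Pyridin-3-yl Replaces Pyrazin-2-yl in Compound 3

The source may hold more compounds than are shown below. What is called first, only, known or untested is meant among the compounds shown, and "the series" means these compounds.

Compound 1 `CCn1nnc(-c2sc(-c3cnccn3)nc2O)n1` was tested in an assay on HEK293 cells for inhibition of transient receptor potential cation channel subfamily M member 8 (Homo sapiens), read by FLIPR, with stated times of 5 min and 3 min (a lower number here means a stronger inhibitor, a higher number a weaker inhibitor), where compound 1 gives 1890 nM. Compound 2 `CCOC(=O)c1sc(-c2ccccc2)nc1NC(=O)C(F)(F)F`, built quite differently, gives 7700 nM in this assay, so compound 1 holds the lower of the two numbers, and the gap between them lies beyond the scatter. Compound 3 `CCn1nnc(-c2sc(-c3cccnc3)nc2O)n1` differs from compound 1 in one place: pyridin-3-yl in place of pyrazin-2-yl on an aromatic carbon. Among the compounds with values here, no measured pair isolates this change. The step of a 1.2-fold higher number from compound 1 to compound 3 (0.07 log units; within the scatter) is expected to lie within the scatter or only slightly beyond it. Compound 3 is estimated at 2200 nM, within a range from 700 nM to 7000 nM.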

Compound 3, half-maximal inhibitory concentration: 1370 nM
Estimate against measurement, compound 3: 1.6-fold (0.21 log units) above; the range from low to high includes it.
By their numbers in this assay, from the lowest: compounds 3 and 1 (each within the scatter of the next); then compound 2.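

In this assay, replacing pyrazin-2-yl with pyridin-3-yl gives a 1.4-fold lower number from compound 1 to compound 3 (0.14 log units; within the scatter), so the numbers do not separate the two groups. At this position, next to the ring nitrogen and the ring sulfur, a six-membered aromatic ring with 1 hetero atom therefore reads the same as one with 2 hetero atoms. Nothing measured here explains this result. The compounds shown leave open whether the position accepts anything other than these two aromatic rings, such as a piperidin-1-yl amine or a carboxylic acid.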